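Thiophen-2-yl replacing 2,4-dichlorophenyl: working notes

The compounds below may be only part of what the source reports. "The series", "measured", "known", "first", "only" and "open" are said of these compounds alone.

Among the measured compounds shown here, compound 2 (`O=C(O)CC/C=C\CC1COC(c2ccc(Cl)cc2Cl)OC1c1cccnc1`) gives 891 nM in a functional assay for inhibition, with Homo sapiens as the target (on this read-out lower numbers stand for tighter binding and higher numbers for weaker binding), and holds the higher of the two numbers so far, while compound 1 (`N#Cc1ccccc1C1OCC(C/C=C\CCC(=O)O)C(c2cccnc2)O1`) gives 245 nM there. Compound 3 (`O=C(O)CC/C=C\CC1COC(c2cccs2)OC1c1cccnc1`) has thiophen-2-yl in place of 2,4-dichlorophenyl on the saturated ring carbon between two ring oxygen atoms (thiophen-2-yl in place of 2,4-dichlorophenyl on a saturated ring carbon). For the measured compounds named here, the one measured step at that carbon (a 3.6-fold higher number from compound 1 to compound 2 (0.56 log units; beyond the scatter)) was modest and left compound 2 on the high side. Thiophen-2-yl has no measured precedent here, so only a small shift toward a lower number is expected (a 1.8-fold lower number from compound 2 to compound 3 (0.25 log units; within the scatter)). For compound 3 the estimated value is 500 nM (range 170 nM to 1500 nM).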

Compound 3, dissociation constant: 1000 nM
Compound 3: the middle estimate sits 2.0-fold (0.30 log units) below what was measured; the measured number falls inside the stated range.
By their numbers in this assay, from the lowest: compound 1; then compounds 2 and 3 (each within the scatter of the next).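

At the saturated ring carbon between two ring oxygen atoms, thiophen-2-yl and 2,4-dichlorophenyl cannot be told apart in this assay, with a 1.1-fold higher number from compound 2 to compound 3 (0.05 log units; within the scatter), despite the change of aromatic ring and of heavy-atom count. 2-Cyanophenyl alone stands apart so far: thiophen-2-yl in its place gives a 4.1-fold higher number from compound 1 to compound 3 (0.61 log units; beyond the scatter), in line with the earlier step to 2,4-dichlorophenyl. No supporting data bear on why these steps come out this way.

As far as these compounds go, whether the nitrile itself carries the difference remains open, as does how unsubstituted phenyl or furan-2-yl would read at this carbon.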